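Cyano in place of chloro: compound 1 to compound 3

A few compounds are considered here, and "the series" means these few. Any claim that something is new, unique, unknown or untested is made for them only; others in the source may bear on it.

Measured so far:
compound 1 `Nc1ccccc1NC(=O)c1ccc(CSC(=S)N2CCN(c3ccc(Cl)cc3)CC2)cc1`: 44.8%
compound 2 `Nc1ccccc1NC(=O)c1ccc(CSC(=S)N2CCc3cc(Cl)ccc32)cc1`: 65.1%

In a functional assay on HeLa cells (Homo sapiens) for antiproliferative activity, read by CCK-8 assay, with a stated time of 72 h, tested at 8 uM (on this read-out lower numbers stand for a weaker effect and higher numbers for a stronger effect at the one concentration tested), compound 1 gives 44.8%, the lower of the two numbers. Compound 2 gives 65.1%, a gap beyond the scatter. Compound 3 `N#Cc1ccc(N2CCN(C(=S)SCc3ccc(C(=O)Nc4ccccc4N)cc3)CC2)cc1` is not yet measured and differs from compound 1 in one place: cyano in place of chloro on an aromatic carbon. For the measured compounds named here, no measured pair shares this change, so the expectation rests on compound 1 alone. The step is expected to read a number 0.2 percentage points higher from compound 1 to compound 3 (within the scatter), not beyond the scatter. Compound 3 is estimated at 45%, in a range from 30% to 62%.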

Compound 3, a percentage reported as inhibition, at one concentration (the size of the read-out at that concentration, not a potency): 70.6%
Beside the measured number, compound 3's estimate is 25.6 percentage points below it; the measured number lies above the stated range.
By their numbers in this assay, from the lowest: compound 1; then compounds 2 and 3 (each within the scatter of the next).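

In this assay the change from 4-chlorophenyl to 4-cyanophenyl reads a number 25.8 percentage points higher from compound 1 to compound 3 (beyond the scatter) and shows that the read-out responds to the group on this aromatic carbon, para to a large group. The earlier compounds shown here held chloro here wherever this ring was present, so they could not show this. No measurement given bears on the reason for the step.

Going by these compounds, whether the response is specific to cyano remains open, since an amine, a carboxylic acid or a methoxy group at this place would test that. On these data alone, whether the same change carries over to the core of compound 2 also remains open.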